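The source may report more compounds than this note shows. Statements on the series, on what has been measured and on what is new or still open speak of the compounds shown alone.

Compound 1 `C=C(Br)C(=O)Nc1cccc(/C=C2\SC(=O)N(Cc3ccc(Cl)cc3)C2=O)c1` gives 1600 nM in a functional assay on FM3A cells (Mus musculus) for cytotoxicity, read by cell counting, with a stated time of 2 days; on this read-out lower numbers stand for stronger inhibition and higher numbers for weaker inhibition.
Compound 2 `C=C(Br)C(=O)Nc1cccc(/C=C2\SC(=O)N(Cc3ccc(C)cc3)C2=O)c1` gives 1000 nM in this assay.
Compound 3 `Nc1cccc(/C=C2\SC(=O)N(Cc3cccc(F)c3)C2=O)c1` is reported only as a limit of the assay, > 250000 nM in this assay.

Going by the values given here, of the two numbers known, compound 2 has the lower one, though compound 1 lies within the scatter of it: a 1.6-fold lower number from compound 1 to compound 2 (0.20 log units; within the scatter). Compound 3 stands at a limit (the limit of > 250000 nM in this assay, at which 1 of the 3 values shown sits), and it differs from compound 2 in more than one place, so it says nothing about the step at hand. Compound 4 `C=C(Br)C(=O)Nc1cccc(/C=C2\SC(=O)N(Cc3ccc(F)cc3)C2=O)c1` differs from compound 2 in one place: fluoro in place of methyl on an aromatic carbon. Among the compounds with values here, the only measured step at that position, chloro to methyl, lay within the scatter, so no shift beyond the scatter is expected here either. The number of compound 2 is expected to carry over nearly unchanged to compound 4, a 1.3-fold higher number from compound 2 to compound 4 (0.11 log units; within the scatter). Compound 4 is therefore estimated at 1300 nM in this assay, with a range from 500 nM to 3500 nM.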

Compound 4, half-maximal inhibitory concentration: 920 nM
Beside the measured number, compound 4's estimate is 1.4-fold (0.15 log units) above it; measured number inside the range.
By their numbers in this assay, from the lowest: compounds 4, 2 and 1 (each within the scatter of the next). At a limit, above all of these: compound 3.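

The step of a 1.1-fold lower number from compound 2 to compound 4 (0.04 log units; within the scatter) in this assay shows that a second change at this position also stays within the scatter, and so does the step of a 1.7-fold lower number from compound 1 to compound 4 (0.24 log units; within the scatter), which compares fluoro directly with chloro. Chloro, methyl and fluoro on this aromatic carbon therefore read alike in all three pairs, where only one pair could be read before. No measured property given here bears on this result.

Going by these compounds, it remains open how an amine, a carboxylic acid or a longer chain on this carbon would read.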